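The compounds below may be only part of what the source reports. "The series", "measured", "known", "first", "only" and "open" are said of these compounds alone.

Compound 1 `NCC(N)CC(=O)N1CCN(C(=O)CCn2cccc(O)c2=O)CC1` and compound 2 `NCC(N)CCC(=O)N1CCN(C(=O)CCn2cccc(O)c2=O)CC1` share one core; compound 3 `NCC(N)CCCNC(=O)CCn1cccc(O)c1=O` rests on a core whose difference from that of compound 1 is not broken down here. In a physicochemical assay, read by spectrophotometry, with a stated time of 10 min, tested at 1 mM, in the presence of a further agent that is not named here (a higher number here means a stronger effect of the compound at the concentration tested, a lower number a weaker effect), compound 1 gives 75.1% and compound 2 gives 74.6%, so that the change 2,3-diaminopropyl in place of 1,2-diaminoethyl on a saturated chain carbon bound to a carbonyl carbon made the step of a number 0.5 percentage points lower from compound 1 to compound 2 (within the scatter). In this assay compound 3 gives 76.4%. Compound 4 `NCC(N)CCCCNC(=O)CCn1cccc(O)c1=O` arises from compound 3 by the same kind of change, (2,3-diaminopropyl in place of 1,2-diaminoethyl on a saturated chain carbon, three bonds along the chain from an amide-type nitrogen), though here the place is a saturated chain carbon three bonds along the chain from an amide-type nitrogen rather than one bound to a carbonyl carbon. Because a number 0.5 percentage points lower from compound 1 to compound 2 (within the scatter) stayed within the scatter, the step of a number 1.4 percentage points lower from compound 3 to compound 4 (within the scatter) is expected to be equally small. Compound 4 is thus estimated at 75% in this assay, between 65% and 84%.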

Compound 4, a percentage reported as activity, at one concentration (the size of the read-out at that concentration, not a potency): 85.6%
For compound 4 the middle estimate is 10.6 percentage points below the measured one, and the stated range ends below it.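

In this assay the change from 1,2-diaminoethyl to 2,3-diaminopropyl gives a number 0.5 percentage points lower from compound 1 to compound 2 (within the scatter) on one core and a number 9.2 percentage points higher from compound 3 to compound 4 (within the scatter) on the other. Both steps lie within the usual scatter, so on neither core can the change be told apart from repeat variation, which is consistent with it carrying across these two cores but does not show that it carries as a step of fixed size. With only these two pairs, nothing shown bears on the reason for either step. The compounds shown leave open how a longer chain such as 3,4-diaminobutyl would read on either core. They also leave open what a carboxylic acid in place of the diamino chain would give.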